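The source may report more compounds than this note shows. Statements on the series, on what has been measured and on what is new or still open speak of the compounds shown alone.

In an assay on cells with melanin-concentrating hormone receptor 1 (Homo sapiens) as the target, read by radioligand binding (a higher number here means a weaker inhibitor, a lower number a stronger inhibitor), compound 1 `CCOCCOc1cccc2ccc(N)nc12` gives > 2000 nM, which is a limit of the assay rather than a number. Compound 2 `Nc1ccc2cccc(OCCC3CCCCC3)c2n1` gives 808 nM in this assay. Compound 3 `CC#CCCOc1cccc2ccc(N)nc12` gives > 2000 nM, again a limit of the assay and not a number. Compound 3 thus stands at the weak end of what has been measured, and the limit of > 2000 nM in this assay, at which 2 of the 3 values shown sit, is where it sits. Among the measured steps, an at least 2.4-fold lower number from compound 1 to compound 2 (0.39 log units; beyond the scatter) brings a stronger number with cyclohexyl in place of ethoxy on a saturated chain carbon, two bonds along the chain from an oxygen on an aromatic ring, while an at least 2.4-fold higher number from compound 2 to compound 3 (0.39 log units; beyond the scatter) gives that gain back. The step that the two limits leave unreadable from compound 1 to compound 3 cannot be sized from two limits.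

Compound 4 `Nc1ccc2cccc(OCCC(F)(F)F)c2n1` differs from compound 3 by trifluoromethyl in place of prop-1-yn-1-yl on a saturated chain carbon, two bonds along the chain from an oxygen on an aromatic ring. Of the measured steps, an at least 2.4-fold higher number from compound 2 to compound 3 (0.39 log units; beyond the scatter) bears most on this change: a small chain group at this place sat at the limit, and the ethoxy of compound 1 sat there too, with only the cyclohexyl of compound 2 rising above it. Trifluoromethyl is another small group at the same place, so the step that the limit leaves unreadable from compound 3 to compound 4 is expected to show nothing beyond the scatter. Compound 4 is therefore estimated at 3000 nM, with a range from 1000 nM to 10000 nM.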

Compound 4, half-maximal inhibitory concentration: 722 nM
Beside the measured number, compound 4's estimate is 4.2-fold (0.62 log units) above it; measured number outside the range, below it.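

In this assay, a chain end without a ring need not stay at the limit: trifluoromethyl gives an at least 2.7-fold lower number from compound 3 to compound 4 (0.44 log units; beyond the scatter) against prop-1-yn-1-yl, and an at least 2.7-fold lower number from compound 1 to compound 4 (0.44 log units; beyond the scatter) against ethoxy. Among the earlier compounds only the cyclohexyl of compound 2 had come off the limit, yet a 1.1-fold lower number from compound 2 to compound 4 (0.05 log units; within the scatter) leaves trifluoromethyl and cyclohexyl indistinguishable, so a ring at this place is not required for a measurable number. The two steps that start from a limit give only a least size, and the real gaps may be larger: the limit of > 2000 nM in this assay, at which 2 of the 4 values shown sit.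

The compounds shown leave open whether this gain belongs to the fluorine atoms or to the shape of the group as a whole, which a plain methyl or a tert-butyl at the same place could help to separate. Also open, on these data alone, is whether a longer chain ending in trifluoromethyl, or an amine or a carboxylic acid in its place, would keep this number or lose it.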